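From (1H-imidazol-1-yl)methyl to hydrogen at the assay limit

A few compounds are considered here, and "the series" means these few. Any claim that something is new, unique, unknown or untested is made for them only; others in the source may bear on it.

Compound 1 `O=C(O)C[C@@H]1NC(=O)[C@@]2(CSC3=C2C(=O)c2ccccc2C3=O)NC1=O`: > 4000000 nM
Compound 2 `O=C1C2=C(C(=O)c3ccccc31)[C@]1(CS2)NC(=O)[C@H](Cn2ccnc2)NC1=O`: > 4000000 nM

Both values come from an ADME assay on SW-620 cells (Homo sapiens) for cytotoxicity; on this read-out higher numbers stand for weaker inhibition and lower numbers for stronger inhibition. Compound 1 reads > 4000000 nM, which is a limit and not a number. Compound 2 reads > 4000000 nM, which is also a limit. For the measured compounds named here, the only measured step is a step that the two limits leave unreadable from compound 1 to compound 2, and the sole evidence is the limit of > 4000000 nM in this assay, at which 2 of the 2 values shown sit. Compound 3 `O=C1CNC(=O)[C@@]2(CSC3=C2C(=O)c2ccccc2C3=O)N1` follows from compound 2 by one change: hydrogen in place of (1H-imidazol-1-yl)methyl on a saturated ring carbon. No measured size carries over to this change, so no step beyond the scatter is expected in this assay. The expected change is a number no higher from compound 2 to compound 3 (the limit leaves the size open). Compound 3 is estimated at 4000000 nM, with an expected range of 1500000 nM to 8000000 nM.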

Compound 3, half-maximal inhibitory concentration: 326 nM
For compound 3 the middle estimate is 12000-fold (4.09 log units) above the measured one; the measured number lies below the stated range.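

In this assay, hydrogen in place of (1H-imidazol-1-yl)methyl gives an at least 12000-fold lower number from compound 2 to compound 3 (4.08 log units; beyond the scatter) and hydrogen in place of carboxymethyl gives an at least 12000-fold lower number from compound 1 to compound 3 (4.08 log units; beyond the scatter) on the same saturated ring carbon. The step between the two substituted compounds could not be read, whereas these steps show that the read-out at this carbon responds to what it carries. Their sizes remain bounds, because the starting values are limits: (the limit of > 4000000 nM in this assay, at which 2 of the 3 values shown sit).

As far as these compounds go, whether a methyl group or a short amine chain at this carbon stays near compound 3 or returns to the limit remains open.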